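This account rests on a few compounds, and the source may have more. Where it says the series, first, only, none or still open, it means among the compounds named here.

Compound 1 `CCc1ccc(-c2nc(N)c3cc(Cc4ccccc4)sc3n2)o1` was tested in a functional assay on CHO-K1 cells for antagonist activity at adenosine receptor A1 (Homo sapiens), read by a beta-galactosidase reporter and cAMP accumulation, with stated times of 15 min and 6 h (a lower number here means a stronger inhibitor, a higher number a weaker inhibitor), where compound 1 gives 223 nM. Among the values shown, this is the only actual number; the other reading is a limit. Compound 2 `C=C(c1ccccc1)c1cc2c(N)nc(-c3cccc(C#N)c3)nc2s1` in this assay gives > 1000 nM, which is a limit of the assay rather than a measured number (the limit of > 1000 nM in this assay, at which 1 of the 2 values shown sits). Compound 3 `Nc1nc(-c2cccc(F)c2)nc2sc(Cc3ccccc3)cc12` has not yet been measured. It differs from compound 1 in one place: 3-fluorophenyl in place of 5-ethylfuran-2-yl on an aromatic carbon. Within the data shown here, no step between two measured compounds is available to guide the size of this change, so the expectation rests on compound 1 and on the structural change alone. In this assay the step of a 1.8-fold higher number from compound 1 to compound 3 (0.25 log units; within the scatter) is expected to be modest, leaning toward a weaker inhibitor, yet close to the usual scatter. Compound 3 is estimated at 400 nM, with a range from 100 nM to 2000 nM.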

Compound 3, inhibition constant: 123 nM
Estimate against measurement, compound 3: 3.3-fold (0.51 log units) above; measured number inside the range.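

In this assay the step is a 1.8-fold lower number from compound 1 to compound 3 (0.26 log units; within the scatter) and stays within the usual scatter, so the assay does not tell these two groups apart at this position on the shared core. The position therefore takes either a furan ring bearing an ethyl group or a fluorine-bearing benzene ring with no clear change in the reading, and the furan oxygen, the one hydrogen-bond acceptor in the leaving group, is not required for a reading of this size. Nothing shown here explains why the two groups read alike.

On these data alone, both groups are aromatic rings, so it remains open whether a non-aromatic group at this position, such as a simple amine or a carboxylic acid, would read the same. The compounds shown also leave open whether plain phenyl or 4-fluorophenyl would fit this pattern.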